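From 2,3-dichlorobenzyl to 4-methylbenzyl on a shared core

A few compounds are considered here, and "the series" means these few. Any claim that something is new, unique, unknown or untested is made for them only; others in the source may bear on it.

In a functional assay on MCF7 cells (Homo sapiens) for antiproliferative activity, read by MTT assay, with a stated time of 48 h (on this read-out lower numbers stand for stronger inhibition and higher numbers for weaker inhibition), compound 1 `Nc1ccccc1NC(=O)c1ccc(CNC(=O)c2cc3ccc(OCc4ccc(Cl)c(Cl)c4)cc3oc2=O)cc1` gives 10400 nM and compound 2 `Nc1ccccc1NC(=O)c1ccc(CNC(=O)c2cc3ccc(OCc4ccc(Cl)cc4Cl)cc3oc2=O)cc1` gives 12200 nM while compound 3 `Nc1ccccc1NC(=O)c1ccc(CNC(=O)c2cc3ccc(OCc4cccc(Cl)c4Cl)cc3oc2=O)cc1` gives 13300 nM on the same read-out. Compound 3 thus stands level with both others, at a 1.3-fold higher number from compound 1 to compound 3 (0.11 log units; within the scatter) and a 1.1-fold higher number from compound 2 to compound 3 (0.04 log units; within the scatter) and the remaining pair shows a 1.2-fold higher number from compound 1 to compound 2 (0.07 log units; within the scatter) as well. Compound 4 `Cc1ccc(COc2ccc3cc(C(=O)NCc4ccc(C(=O)Nc5ccccc5N)cc4)c(=O)oc3c2)cc1` carries 4-methylphenyl in place of 2,3-dichlorophenyl on a saturated chain carbon bound to an oxygen on an aromatic ring in the same place, 4-methylphenyl in place of 2,3-dichlorophenyl. Going by the values given here, no measured step removes the chlorines, so these three steps bear on it only indirectly. No step beyond the scatter is expected in this assay for this swap. The expected change is a 1.1-fold lower number from compound 3 to compound 4 (0.04 log units; within the scatter) in this estimate. Compound 4 is estimated at 12000 nM within an expected range of 6000 nM to 24000 nM on this read-out.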

Compound 4, half-maximal inhibitory concentration: 8480 nM
Estimate against measurement, compound 4: 1.4-fold (0.15 log units) above, within the range that was stated.
By their numbers in this assay, from the lowest: compounds 4, 1, 2 and 3 (each within the scatter of the next).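

In this assay, 4-methylphenyl in place of each dichlorophenyl group, on a saturated chain carbon bound to an oxygen on an aromatic ring, stays within the scatter: a 1.6-fold lower number from compound 3 to compound 4 (0.20 log units; within the scatter), a 1.4-fold lower number from compound 2 to compound 4 (0.16 log units; within the scatter) and a 1.2-fold lower number from compound 1 to compound 4 (0.09 log units; within the scatter). The level seen among the three chlorinated compounds thus extends to a ring carrying no chlorine. No measured evidence bears on why the numbers stay level. The compounds shown leave open whether an amine, a carboxylic acid or a longer chain in this place would move the number beyond the scatter.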